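The source may report more compounds than this note shows. Statements on the series, on what has been measured and on what is new or still open speak of the compounds shown alone.

Working notes on the series. The shared core carries an amide-linked aryl ether; compound 1 `O=C(Nc1ccc(Oc2ccnc3[nH]ccc23)c(F)c1)c1cc2cccnc2n(-c2ccc(F)cc2)c1=O`, compound 2 `Cn1ccc2c(Oc3ccc(NC(=O)c4cc5cccnc5n(-c5ccc(F)cc5)c4=O)cc3)ccnc21` and compound 3 `Cn1ccc2c(Oc3ccc(NC(=O)c4cc5cccnc5n(-c5ccccc5)c4=O)cc3F)ccnc21` have been run in a functional assay on HT-29 cells (Homo sapiens) for antiproliferative activity, read by MTT assay, with a stated time of 72 h; on this read-out higher numbers stand for weaker inhibition and lower numbers for stronger inhibition. In this assay compound 1 gives 36 nM, compound 2 gives 250 nM and compound 3 gives 510 nM. Compound 3 thus stands highest of the three numbers: its gap to compound 2 is the smaller one and lies beyond the scatter, and its gap to compound 1 is the larger and also lies beyond the scatter. Compound 4 `Cn1ccc2c(Oc3ccc(NC(=O)c4cc5cccnc5n(-c5ccc(F)cc5)c4=O)cc3F)ccnc21` is not yet measured in this assay. It differs from compound 3 by fluoro in place of hydrogen on an aromatic carbon; read one bond further out, the change is phenyl to 4-fluorophenyl, on a six-membered aromatic ring of carbon only, para to a large group. Among the compounds with values here, no pair of measured compounds isolates this change on its own, so no step for it is known. Compound 2 carries the same 4-fluorophenyl group and gives 250 nM, a lower number than compound 3, which is the only lead available. Compound 4 is therefore expected to give 300 nM, with a range of 120 nM to 800 nM. The step from compound 3 to compound 4 is estimated as a 1.7-fold lower number from compound 3 to compound 4 (0.23 log units; within the scatter), a modest move toward a lower number that may not clear the scatter.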

Compound 4, half-maximal inhibitory concentration: 160 nM
Compound 4: the middle estimate sits 1.9-fold (0.27 log units) above what was measured, within the range that was stated.
By their numbers in this assay, from the lowest: compound 1; then compounds 4 and 2 (each within the scatter of the next); then compound 3.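

In this assay, phenyl to 4-fluorophenyl, para to a large group, now stands as an isolated step, a 3.2-fold lower number from compound 3 to compound 4 (0.50 log units; beyond the scatter) and thus a real gain from this one fluoro at this position. Fluoro in place of hydrogen on another aromatic carbon gives a 1.6-fold lower number from compound 2 to compound 4 (0.19 log units; within the scatter) and does not separate those two compounds, so the fluoro on the phenyl is the one that registers here. Methyl in place of hydrogen on an aromatic nitrogen gives a 4.4-fold higher number from compound 1 to compound 4 (0.65 log units; beyond the scatter) with the 4-fluorophenyl kept, so compound 1, with hydrogen on that nitrogen, retains the lower number.

No measurement at hand accounts for any of these steps. Open, as far as these compounds go, are whether chloro, methoxy or an amine in the same place would follow fluoro, and whether the fluoro step holds with hydrogen on that nitrogen.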